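The compounds below may be only part of what the source reports. "The series", "measured", "known", "first", "only" and "open" are said of these compounds alone.

Of the compounds shown here, three built on a shared core have been measured in an assay on isolated protein for inhibition of Amine oxidase [flavin-containing] B (Homo sapiens); a higher number here means a weaker inhibitor, a lower number a stronger inhibitor. Compound 1 `C#CCNC1CCc2c(SCc3cccc(OC)c3)cccc21` gives 3190 nM in this assay. Compound 2 `C#CCNC1CCc2c(SCCc3ccc(F)c(F)c3)cccc21` gives 3240 nM in this assay, the highest of the three numbers, although its gap to compound 1 lies within the usual scatter, so those two cannot be placed in order. Compound 3 `C#CCNC1CCc2c(SCc3ccc(Br)cc3)cccc21` gives 1310 nM in this assay, a number below that of compound 2 by more than the scatter.

Compound 4 `C#CCNC1CCc2c(SCCc3ccc(Cl)c(Cl)c3)cccc21` has not yet been measured. It differs from compound 2 in one place: 3,4-dichlorophenyl in place of 3,4-difluorophenyl on a saturated chain carbon, two bonds along the chain from a sulfur. Among the measured compounds shown here, no measured pair among the three compounds shows this exchange, so there is no step to lean on. On what is known, the change is expected to lower the number slightly, by a step of a 1.8-fold lower number from compound 2 to compound 4 (0.26 log units; within the scatter) in this assay, near the edge of the scatter. Compound 4 is therefore expected to give about 1800 nM in this assay, with a likely range from 700 nM to 4500 nM.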

Compound 4, half-maximal inhibitory concentration: 3850 nM
For compound 4 the middle estimate is 2.1-fold (0.33 log units) below the measured one; the range from low to high includes it.
By their numbers in this assay, from the lowest: compound 3; then compounds 1, 2 and 4 (each within the scatter of the next).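

In this assay, among the compounds shown here, the exchange of 3,4-difluorophenyl for 3,4-dichlorophenyl on a saturated chain carbon, two bonds along the chain from a sulfur, is the first change at this position that can be read directly, and the step is a 1.2-fold higher number from compound 2 to compound 4 (0.07 log units; within the scatter). This assay therefore cannot tell these two groups apart at this position, and compounds 2 and 4 cannot be placed in order. No separate measurement is available that could explain this result.

What the compounds shown leave open is whether a ring carrying something other than these halogens, such as an amine or a carboxylic acid, would separate from compounds 2 and 4. From the compounds shown here alone, it is also open whether a longer chain to the sulfur would give the same reading for this exchange.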